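Benzamido gives way to methyl(pyridin-3-yl)amino on the shared core

The source may hold more compounds than are shown below. What is called first, only, known or untested is meant among the compounds shown, and "the series" means these compounds.

In an ADME assay on microsomes from liver (Homo sapiens) for metabolic stability, read by LC-MS, using NADPH, with stated times of 5 min and 30 min, tested at 1 uM (on this read-out higher numbers stand for fast clearance and lower numbers for slow clearance), compound 1 (`Fc1ccc2c(c1CNc1ncc(Oc3ccccc3)c3nncn13)CCO2`) gives 18 mL.min-1.g-1 and compound 2 (`O=C(Nc1cnc(NCc2c(F)ccc3c2CCO3)n2cnnc12)c1ccccc1`) gives 10 mL.min-1.g-1 on the same scale. Among the measured compounds shown here, these are the only two numbers available, and compound 2 cannot be separated from compound 1 on them. For the measured compounds named here, the replacement linking the pair, benzamido in place of phenoxy on an aromatic carbon, amounts to a 1.8-fold lower number from compound 1 to compound 2 (0.26 log units; within the scatter) and is the only measured step at this place.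

Compound 3 (`CN(c1cccnc1)c1cnc(NCc2c(F)ccc3c2CCO3)n2cnnc12`) carries a further change on that same carbon, methyl(pyridin-3-yl)amino in place of benzamido (methyl(pyridin-3-yl)amino in place of benzamido on an aromatic carbon). Going by the values given here, no measured compound holds the entering group, so the evidence is thin. Among the compounds with values here, the one relevant precedent is the step between compound 1 and compound 2 (a 1.8-fold lower number from compound 1 to compound 2 (0.26 log units; within the scatter)), which stayed within the scatter. No step beyond the scatter is therefore expected in this assay here, with at most a slight lean towards a higher number. The estimate amounts to an expected 1.4-fold higher number from compound 2 to compound 3 (0.15 log units; within the scatter) in this comparison. Compound 3 is expected at 14 mL.min-1.g-1 within an estimated range of 6 mL.min-1.g-1 to 32 mL.min-1.g-1 on this read-out.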

Compound 3, intrinsic clearance in microsomes: 80 mL.min-1.g-1
The estimate for compound 3 lay 5.7-fold (0.76 log units) below the measured number, and the stated range ends below it.
By their numbers in this assay, from the lowest: compounds 2 and 1 (each within the scatter of the next); then compound 3.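

In this assay, this aromatic carbon of the shared core now proves able to move the read-out beyond the scatter: methyl(pyridin-3-yl)amino in place of benzamido gives an 8.0-fold higher number from compound 2 to compound 3 (0.90 log units; beyond the scatter), and in place of phenoxy it gives a 4.4-fold higher number from compound 1 to compound 3 (0.65 log units; beyond the scatter). Phenoxy and benzamido had stayed within the scatter of each other, so the earlier pair gave no sign that a group at this place could matter so much; the new result shows that the read-out is not indifferent to what sits here. The exchange alters several things at once, replacing a six-membered aromatic ring of carbon only with one holding a hetero atom and bringing a methyl-bearing nitrogen as the link, and nothing available accounts for the rise.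

Which of these features carries the step remains open, since methyl(phenyl)amino would keep the methylated link without the ring nitrogen, while pyridin-3-yloxy would keep the ring nitrogen without that link. Whether a step of this size would also appear with pyridin-3-ylamino, which lacks only the methyl, is equally unsettled.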